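This account rests on a few compounds, and the source may have more. Where it says the series, first, only, none or still open, it means among the compounds named here.

Of the compounds shown here, three that share one core have so far been measured in an ADME assay on a cell-free system (plasma, Homo sapiens) for metabolic stability, read by LC-MS, with a stated time of 60 min, at 37 degrees C, tested at 50 uM; on this read-out higher numbers stand for a more stable compound and lower numbers for a less stable compound. Compound 1 `C[C@@H](O)[C@H]1C(=O)N2C(C(=O)OCOC(=O)C(C)(C)C)=C(S[C@@H]3CN[C@H](C(=O)Nc4cccc(C(=O)O)c4)C3)[C@H](C)[C@H]12` gives 45% in this assay, the highest of the three numbers. Compound 2 `C[C@@H](O)[C@H]1C(=O)N2C(C(=O)OCOC(=O)C(C)(C)C)=C(S[C@@H]3CN[C@H](C(=O)Nc4cccc(C(=O)OCOC(=O)C(C)(C)C)c4)C3)[C@H](C)[C@H]12` carries a (((tert-butyl)carbonyl)oxy)methyl group in place of hydrogen on an oxygen next to a carbonyl group and gives 36% in this assay; the step of a number 9 percentage points lower from compound 1 to compound 2 (within the scatter) lies within the scatter of repeated measurements, so the two compounds cannot be ranked. Compound 3 `C[C@@H](O)[C@H]1C(=O)N2C3=C(S[C@@H]4CN[C@@H](C4)C(=O)Nc4cccc(c4)C(=O)OCc4oc(=O)oc4COC3=O)[C@H](C)[C@H]12`, whose structure is rebuilt more widely, gives 0% in this assay, far below compound 1.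

Compound 4 `C[C@@H](O)[C@H]1C(=O)N2C(C(=O)OCOC(=O)OC(C)(C)C)=C(S[C@@H]3CN[C@H](C(=O)Nc4cccc(C(=O)O)c4)C3)[C@H](C)[C@H]12` differs from compound 1 in one place: tert-butoxy in place of tert-butyl on a carbonyl carbon. Going by the values given here, no measured step changes this position. Among the compounds with values here, the only measured step, from compound 1 to compound 2, touches a different position and stayed within the scatter, while compound 3 shows that a larger rebuild can leave nothing of the compound after the stated time. Within the data shown here, with no direct precedent, only a modest step in this assay is expected, if any, and its direction is uncertain. Compound 4 is therefore estimated at 40%, with a range from 20% to 60%. The expected step is a number 5 percentage points lower from compound 1 to compound 4 (within the scatter).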

Compound 4, percent of the compound remaining: 40%
For compound 4 middle estimate and measured number coincide at the digits printed; the measured number falls inside the stated range.
By their numbers in this assay, from the lowest: compound 3; then compounds 2, 4 and 1 (each within the scatter of the next).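

In this assay, tert-butoxy in place of tert-butyl on a carbonyl carbon gives a number 5 percentage points lower from compound 1 to compound 4 (within the scatter) and so cannot be told apart from no difference at all. Going by these compounds alone, this is the first reading at this position: (((tert-butyl)carbonyl)oxy)methyl becomes ((tert-butoxycarbonyl)oxy)methyl, and the added oxygen and hydrogen-bond acceptor leave no readable mark on the percent of compound remaining. No measurement at hand offers a reason for this result.

Within the data shown here, only this one swap has been seen here, so it remains open whether a group of another kind on the same carbonyl carbon, such as an amine or a longer chain like n-hexyl, would also stay within the scatter of compound 1 or would move beyond it. As far as these compounds go, it is also open whether the same swap would read the same way on the core of compound 2, and which part of the wider rebuild in compound 3 goes with its value of 0% in this assay.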